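The source may hold more compounds than are shown below. What is called first, only, known or untested is meant among the compounds shown, and "the series" means these compounds.

Measured so far:
compound 1, `COc1ccc(/C(Cl)=C/C=C(\C#N)C(=O)c2c(C)[nH]c3ccccc23)cc1`: in a functional assay on MCF7 cells (Homo sapiens) for cytotoxicity, read by sulforhodamine B assay, with a stated time of 48 h (a higher number here means that more compound is tolerated, a lower number that less compound is tolerated), compound 1 gives > 100000 nM
compound 2, `COc1ccc(/C(Cl)=C/C=C(\C#N)C(=O)c2c[nH]c3ccccc23)cc1`: in this assay compound 2 gives > 100000 nM

The value of compound 1 is a limit of the assay, not a number. The value of compound 2 is likewise a limit. Compound 2 differs from compound 1 by hydrogen in place of methyl on an aromatic carbon, and the step that the two limits leave unreadable from compound 1 to compound 2 is therefore unreadable. Both values sit at the limit of > 100000 nM in this assay, at which 2 of the 2 values shown sit. Compound 1 thus stands only at a limit, with no numbered value beside it to set it against.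

Compound 3 is `Cc1[nH]c2ccccc2c1C(=O)/C(C#N)=C/C=C(\Cl)c1ccc(Br)cc1`; it differs from compound 1 by bromo in place of methoxy on an aromatic carbon. Among the compounds with values here, no measured step concerns this change; the single measured step is unreadable and touches another place on the core. There is accordingly nothing that points to a readable step in this assay in either direction beyond the scatter. The expectation is that compound 3 also sits at the limit, so that the step of a number no higher from compound 1 to compound 3 (the limit leaves the size open) is expected to be small. Compound 3 is estimated at 100000 nM, in the range 30000 nM to 300000 nM.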

Compound 3, concentration lethal to 50% of the cells: > 100000 nM
Compound 3: only a limit was reported (the forecaster's own chance of this, stated with the estimate: 75%); the middle value sits exactly at the limit.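

In this assay compound 3 gives > 100000 nM, a limit of the assay and not a number. Compound 1 also stands at a limit, so no new step can be read between compound 1 and compound 3: the limit of > 100000 nM in this assay, at which 3 of the 3 values shown sit. The compounds shown leave open whether bromo in place of methoxy, or any other change on the shared core, shifts the result in this assay at all.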